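Extending a benzyl amide in a calpain inhibitor series

A few compounds are considered here, and "the series" means these few. Any claim that something is new, unique, unknown or untested is made for them only; others in the source may bear on it.

Measured so far:
Compound 1, `CCOC(=O)C(=O)C(CC)NC(=O)C(CC(C)C)NC(=O)CCc1ccccc1`: 1200 nM
Compound 2, `CCOC(=O)C(=O)C(CC)NC(=O)C(CC(C)C)NC(=O)CCCCc1ccccc1`: 1900 nM
Compound 3, `CCC(NC(=O)C(CC(C)C)NC(=O)OCc1ccccc1)C(=O)C(=O)NCc1ccccc1`: 22 nM

The three compounds were tested in an assay on isolated protein (Oryctolagus cuniculus) for inhibition of Calpain-2 catalytic subunit (Homo sapiens), at pH 8.0; on this read-out lower numbers stand for stronger inhibition and higher numbers for weaker inhibition. Compound 1 gives 1200 nM, and compound 2, made by phenethyl in place of phenyl on a saturated chain carbon, two bonds along the chain from a carbonyl carbon, gives 1900 nM; the step of a 1.6-fold higher number from compound 1 to compound 2 (0.20 log units; within the scatter). Compound 3 gives 22 nM and is the strongest inhibitor of the three; the difference between its core and the core of compound 1 is not broken down here.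

Compound 4, `CCC(NC(=O)C(CC(C)C)NC(=O)OCc1ccccc1)C(=O)C(=O)NCCCc1ccccc1`, is not yet measured. It comes from compound 3 by phenethyl in place of phenyl on a saturated chain carbon bound to an amide-type nitrogen. Among the compounds with values here, this is the same kind of change as the one from compound 1 to compound 2, though the place differs: there the carbon sat two bonds along the chain from a carbonyl carbon, here it is bound to an amide-type nitrogen. Because a 1.6-fold higher number from compound 1 to compound 2 (0.20 log units; within the scatter), the expected step is small, a 1.4-fold higher number from compound 3 to compound 4 (0.13 log units; within the scatter). Compound 4 is thus estimated at 30 nM in this assay, expected between 10 nM and 100 nM.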

Compound 4, inhibition constant: 43 nM
Compound 4: middle estimate off by 1.4-fold (0.16 log units), on the low side; low and high end bracket the measured number.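

In this assay, phenethyl in place of phenyl on a saturated chain carbon bound to an amide-type nitrogen gives a 2.0-fold higher number from compound 3 to compound 4 (0.29 log units; within the scatter). Set beside the earlier step, the same change looks alike on both cores: the same change on two cores in this assay, a 1.6-fold higher number (0.20 log units; within the scatter) from compound 1 to compound 2 and a 2.0-fold higher number (0.29 log units; within the scatter) from compound 3 to compound 4, 1.2-fold (0.09 log units) apart, within the scatter of two such steps This shows that the change carried over between these two cores without a step beyond the scatter, but two pairs do not make a rule for other cores in the series.

The compounds shown leave open what a longer chain, or an amine or a carboxylic acid at the end of the chain, would do on either core. Compound 1 and compound 3 differ in more than one place, so what lies behind the gap between them also stays open.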